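The source may hold more compounds than are shown below. What is called first, only, known or untested is meant among the compounds shown, and "the series" means these compounds.

Working notes on the series.

Three compounds have numbers in a functional assay on NCI-H522 cells (Homo sapiens) for cytotoxicity, read by sulforhodamine B assay, with a stated time of 48 h, tested at 10 uM; on this read-out lower numbers stand for a stronger effect and higher numbers for a weaker effect at the one concentration tested. Compound 1 `COc1cc(C)cc(-c2c(-c3ccnc(-c4ccc(C(C)=O)cc4)c3)cnn2CC#N)c1` gives -10% in this assay. Compound 2 `Cc1cc(O)cc(-c2nn(CC#N)cc2-c2ccnc(-c3ccc(Oc4ccccc4)cc3)c2)c1` gives -93% in this assay. Compound 3 `COc1cc(C)cc(-c2nn(CC#N)cc2-c2ccnc(-c3ccc(N(C)C)cc3)c2)c1` gives -64% in this assay. On these three numbers compound 3 stands second highest: the nearest is compound 2, whose number lies lower by a gap beyond the scatter, and the furthest is compound 1, whose number lies higher by a gap beyond the scatter. Among the compounds with values here, no pair among the three differs in only one place, so no single step can be read off between measured compounds; compound 2 and compound 3 differ both in the group on the oxygen and in the substituent on the far aromatic ring.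

The next compound, compound 4 `Cc1cc(O)cc(-c2nn(CC#N)cc2-c2ccnc(-c3ccc(N(C)C)cc3)c2)c1`, is compound 3 with hydrogen in place of methyl on an oxygen on an aromatic ring. Within the data shown here, no measured step of this kind exists. Among the measured compounds shown here, compound 2, the only compound with a hydroxy on that ring, gives the lowest number, but its other difference from compound 3 leaves the contribution of the hydroxy open. A modest step toward lower numbers, at or near the edge of the scatter, is expected from compound 3 to compound 4 in this assay, as a number 11 percentage points lower from compound 3 to compound 4 (beyond the scatter). Compound 4 is therefore estimated at -75% in this assay, with a range from -95% to -45%.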

Compound 4, a percentage reported as activity, at one concentration (the size of the read-out at that concentration, not a potency): -57%
Beside the measured number, compound 4's estimate is 18 percentage points below it, and the stated range covers the measured number.
By their numbers in this assay, from the lowest: compound 2; then compounds 3 and 4 (each within the scatter of the next); then compound 1.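

In this assay the methoxy to hydroxy change now has a direct reading: hydrogen in place of methyl on an oxygen on an aromatic ring gives a number 7 percentage points higher from compound 3 to compound 4 (within the scatter) and so, with dimethylamino on the other aromatic ring, this change leaves the read-out unmoved beyond the scatter. The series also gains its first reading of that other substituent, where dimethylamino in place of phenoxy on an aromatic carbon gives a number 36 percentage points higher from compound 2 to compound 4 (beyond the scatter) and so the low number of compound 2 goes with the phenoxy rather than with the hydroxy, which compound 4 carries as well. Nothing at hand bears on a cause for either step.

Open, as far as these compounds go, is whether the methoxy to hydroxy change reads the same when phenoxy stands on the other ring, since a single pair with dimethylamino cannot settle that. Also open, from the compounds shown here alone, is what an amine, a carboxylic acid or a longer chain such as ethoxy would do on the 5-methylphenyl ring in place of the hydroxy, and what other groups would do in place of phenoxy.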